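Notes on an aryl swap in the series

A few compounds are considered here, and "the series" means these few. Any claim that something is new, unique, unknown or untested is made for them only; others in the source may bear on it.

- compound 1 `OC[C@H]1O[C@@H](n2cnc3c(NCc4ccc(Cl)c(Cl)c4)ncnc32)[C@H](O)[C@@H]1O` gives 10800 nM
- compound 2 `Cc1ccc(O)c(CNc2ncnc3c2ncn3[C@@H]2O[C@H](CO)[C@@H](O)[C@H]2O)c1` gives 16500 nM

Among the measured compounds shown here, in a functional assay on K562 cells (Homo sapiens) for antiproliferative activity, with a stated time of 72 h (on this read-out lower numbers stand for stronger inhibition and higher numbers for weaker inhibition), compound 2 sits within the scatter of compound 1, the only other measured compound. For the measured compounds named here, the change to compound 3 `OC[C@H]1O[C@@H](n2cnc3c(NCc4ccccc4OC(F)F)ncnc32)[C@H](O)[C@@H]1O` is 2-(difluoromethoxy)phenyl in place of 2-hydroxy-5-methylphenyl on a saturated chain carbon bound to a nitrogen on an aromatic ring at the same place as the one measured step. Going by the values given here, that step is a 1.5-fold higher number from compound 1 to compound 2 (0.18 log units; within the scatter) and it is the only evidence here, so no step beyond the scatter is expected in this assay for this change. The expected step is a 1.3-fold lower number from compound 2 to compound 3 (0.10 log units; within the scatter) on this estimate. For compound 3 the estimated value is 13000 nM with an expected range from 5000 nM to 32000 nM in this read-out.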

Compound 3, half-maximal inhibitory concentration: > 166000 nM
Compound 3: no number, only a limit (the forecaster's own chance of this, stated with the estimate: 10%); middle value at least 12-fold (1.10 log units) from the limit.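

The aryl group on a saturated chain carbon bound to a nitrogen on an aromatic ring is not freely exchangeable in this assay: the earlier swap stayed within the scatter, but 2-(difluoromethoxy)phenyl brings an at least 10-fold higher number from compound 2 to compound 3 (1.00 log units; beyond the scatter) and an at least 15-fold higher number from compound 1 to compound 3 (1.18 log units; beyond the scatter). From the compounds shown here alone, both steps therefore exceed the scatter, and their full size remains unknown. Compound 3 has only a limit of the assay, not a number: the limit of > 166000 nM in this assay, at which 1 of the 3 values shown sits.

Which part of the 2-(difluoromethoxy)phenyl group accounts for these steps stays open. Also open, going by these compounds, is how a methoxy group or an amine on that phenyl ring would read in this assay.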